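The source may hold more compounds than are shown below. What is called first, only, known or untested is meant among the compounds shown, and "the series" means these compounds.

Measured so far in an assay on HeLa cells for displacement of a labelled ligand from adenosine receptor A3 (Homo sapiens), read by scintillation counting, with a stated time of 180 min, tested at 10 uM; a lower number here means less inhibition, a higher number more inhibition at the concentration tested (going by the name of the read-out):

compound 1 `COc1cccc2cc(C(=O)NCC(=O)O)c(=O)oc12`: 15%
compound 2 `N=c1oc2ccc(Br)cc2cc1C(=O)NCCO`: 0%
compound 3 `COc1cccc2cc(C(=O)NCCO)c(=N)oc12`: 23%

Among these three numbers compound 1 stands second highest. Its nearest neighbour is compound 3, whose number is higher but only by a gap that lies within the usual scatter of this assay, so the two cannot be told apart. Its furthest neighbour is compound 2, whose number is lower by a gap beyond the scatter; compound 2 shows no inhibition at all at the concentration tested.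

Compound 4 `COc1cccc2cc(C(=O)N[C@@H](CO)C(=O)O)c(=O)oc12` has not yet been measured. It differs from compound 1 in one place: hydroxymethyl in place of hydrogen on a saturated chain carbon bound to an amide-type nitrogen and a carbonyl carbon. Cut one bond further out, the carboxymethyl of compound 1 becomes 1-carboxy-2-hydroxyethyl in compound 4, and the entering group brings one hydrogen-bond donor and one hydrogen-bond acceptor.

Going by the values given here, no pair of measured compounds differs in a single place, so nothing measured here shows what such an addition does. The expected step from compound 1 to compound 4 in this assay is therefore small, no change at the digits printed from compound 1 to compound 4 (within the scatter), with no direction that can be trusted beyond the scatter. For compound 4 the estimate is 15%, in a range from 0% to 35%.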

Compound 4, a percentage reported as inhibition, at one concentration (the size of the read-out at that concentration, not a potency): 3%
Beside the measured number, compound 4's estimate is 12 percentage points above it; low and high end bracket the measured number.
By their numbers in this assay, from the lowest: compounds 2 and 4 (each within the scatter of the next); then compounds 1 and 3 (each within the scatter of the next).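

Going by these compounds alone, replacing hydrogen with hydroxymethyl on the saturated chain carbon bound to an amide-type nitrogen and a carbonyl carbon gives, in this assay, a number 12 percentage points lower from compound 1 to compound 4 (beyond the scatter), the first single-place change that can be read in this set. It shows that this chain carbon is not indifferent to substitution, and that here an added group bringing a hydrogen-bond donor and a hydrogen-bond acceptor goes with less inhibition at the concentration tested, although this rests on one pair and the read-out is not a potency. Nothing available here explains why the number falls.

The compounds shown leave open whether the step belongs to the oxygen of hydroxymethyl or to any group added at this carbon, a question that a methyl or an aminomethyl in the same place could help to separate. Also open, going by these compounds, is how a longer chain, such as 2-hydroxyethyl, would behave there, and whether the same step would appear on a different core.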